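The compounds below may be only part of what the source reports. "The series", "measured", "known", "first", "only" and "open" are said of these compounds alone.

Series notes, demethylation on the aromatic oxygen.

Compound 1 `COc1cccc(/C=C/C(C)=O)c1O` is the reference. In a functional assay for inhibition, with Oryctolagus cuniculus as the target (a higher number here means a weaker inhibitor, a lower number a stronger inhibitor), compound 1 gives 3250 nM. Compound 2 `CC(=O)/C=C/c1cccc(O)c1O` is its demethylated counterpart; in this assay compound 2 gives 1960 nM. The change is hydrogen in place of methyl on an oxygen on an aromatic ring and the step it made was a 1.7-fold lower number from compound 1 to compound 2 (0.22 log units; within the scatter).

Compound 3 `COc1ccc(O)c(/C=C/C(C)=O)c1` carries the same atoms as compound 1 joined differently; the difference between the two cores is not broken down here. In this assay compound 3 gives 3980 nM, which sits within the scatter of compound 1 and beyond the scatter of compound 2.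

Compound 4 `CC(=O)/C=C/c1cc(O)ccc1O` is not yet measured. It stands to compound 3 as compound 2 stands to compound 1: the change is hydrogen in place of methyl on an oxygen on an aromatic ring, the same change as before, made on the same kind of place. With one prior instance only, the expectation rests on compound 1 and its step of a 1.7-fold lower number from compound 1 to compound 2 (0.22 log units; within the scatter). Going by the values given here, compound 4 is therefore expected to move by a 1.7-fold lower number from compound 3 to compound 4 (0.22 log units; within the scatter) in this assay, with wide bounds because the single measured step lies within the scatter. For compound 4 the estimate in this assay is 2400 nM, between 1200 nM and 5000 nM.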

Compound 4, half-maximal inhibitory concentration: 1430 nM
Estimate against measurement, compound 4: 1.7-fold (0.22 log units) above; the range from low to high includes it.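

In this assay the change from methoxy to hydroxy on the core of compound 3 gave a 2.8-fold lower number from compound 3 to compound 4 (0.44 log units; beyond the scatter), the same direction as on the core of compound 1. The two steps cannot be told apart in size, so on the present data the change carries across these two cores as one effect: the same change on two cores in this assay, a 1.7-fold lower number (0.22 log units; within the scatter) from compound 1 to compound 2 and a 2.8-fold lower number (0.44 log units; beyond the scatter) from compound 3 to compound 4, 1.7-fold (0.22 log units) apart, within the scatter of two such steps

This supports only a modest lower number on these two cores, with just one of the two steps beyond the scatter, and it does not show why the number falls or that the change would behave alike on any further core.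

The compounds shown carry only methoxy or hydroxy at this place, so it stays open how an ethoxy group, a longer alkoxy chain or an amine would read in this assay. Also open, as far as these compounds go, is whether any such replacement would follow the same direction on both cores.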